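A few compounds are considered here, and "the series" means these few. Any claim that something is new, unique, unknown or untested is made for them only; others in the source may bear on it.

In a functional assay on HCT-116 cells (Homo sapiens) for antiproliferative activity, read by MTT assay, with a stated time of 48 h (a lower number here means a stronger inhibitor, a higher number a weaker inhibitor), compound 2 `COc1ccc(Nc2ncc(C)c(Nc3nc4ccccc4s3)n2)cc1` gives only > 50000 nM, which is a limit of the assay rather than a measured number. Compound 1 `Cc1cnc(Nc2ccc(F)cc2)nc1Nc1nc2ccccc2s1` likewise gives > 50000 nM, again a limit. The step that the two limits leave unreadable from compound 1 to compound 2 therefore cannot be read. Compound 3 `Cc1cnc(Nc2ccc(N3CCCCC3)cc2)nc1Nc1nc2ccccc2s1` differs from compound 2 by piperidin-1-yl in place of methoxy on an aromatic carbon. Among the measured compounds shown here, the single measured step concerns a different change and is unreadable because of the limit of > 50000 nM in this assay, at which 2 of the 2 values shown sit, so no size or direction beyond the scatter can be expected from it. The step of a number no higher from compound 2 to compound 3 (the limit leaves the size open) is expected to be flat. Compound 3 is estimated at 50000 nM, ranging from 10000 nM to 100000 nM.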

Compound 3, half-maximal inhibitory concentration: 18700 nM
Compound 3: the middle estimate sits 2.7-fold (0.43 log units) above what was measured; the measured number falls inside the stated range.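

In this assay, this aromatic carbon proves able to move the read-out: piperidin-1-yl gives an at least 2.6-fold lower number from compound 2 to compound 3 (0.42 log units; beyond the scatter) against methoxy, and an at least 2.6-fold lower number from compound 1 to compound 3 (0.42 log units; beyond the scatter) against fluoro. The step between fluoro and methoxy cannot be read, so those two groups cannot be ordered. Both new steps give only a minimum size, and their full size stays unknown: the limit of > 50000 nM in this assay, at which 2 of the 3 values shown sit.

As far as these compounds go, whether the ring of piperidin-1-yl or its nitrogen matters more remains open. So does how a morpholine, a dimethylamino group or a carboxylic acid would read at this place.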